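Moving a chlorine on the benzyl group of compound 3

The source may hold more compounds than are shown below. What is called first, only, known or untested is meant among the compounds shown, and "the series" means these compounds.

Measured so far:
- compound 1 `CCCCNc1nc(N)nc2c1CN(C)CC2`: 0.03 uM
- compound 2 `CCCCNc1nc(N)nc2c1CN(Cc1ccccc1Cl)CC2`: 0.05 uM
- compound 3 `CCCCNc1nc(N)nc2c1CN(Cc1cccc(Cl)c1Cl)CC2`: 0.18 uM

All three were tested in an assay on HEK293 cells for agonist activity at Toll-like receptor 8 (Homo sapiens), read by a luciferase reporter, with a stated time of 6 h; on this read-out lower numbers stand for an effect already at smaller amounts and higher numbers for an effect only at larger amounts of compound. Among them compound 3 gives the highest number: compared with compound 2 it lies a 3.6-fold higher number from compound 2 to compound 3 (0.56 log units; beyond the scatter), and compared with compound 1 it lies a 6.0-fold higher number from compound 1 to compound 3 (0.78 log units; beyond the scatter), both beyond the scatter. The step from compound 1 to compound 2, adding 2-chlorophenyl on the saturated chain carbon bound to the amine nitrogen in the ring, was a 1.7-fold higher number from compound 1 to compound 2 (0.22 log units; within the scatter).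

Compound 4 `CCCCNc1nc(N)nc2c1CN(Cc1c(Cl)cccc1Cl)CC2` keeps the same atoms as compound 3 but joins them differently: 2,6-dichlorophenyl in place of 2,3-dichlorophenyl on a saturated chain carbon bound to an amine nitrogen in a ring. Among the measured compounds shown here, no measured pair shows what moving a chlorine within the ring does; the only chlorine-related step, from compound 2 to compound 3, concerns adding one. The expectation is therefore a step of a 1.2-fold lower number from compound 3 to compound 4 (0.08 log units; within the scatter), that is, no clear change beyond the scatter. Compound 4 is estimated at 0.15 uM, with a range from 0.05 uM to 0.5 uM.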

Compound 4, minimum effective concentration: 0.14 uM
The estimate for compound 4 lay 1.1-fold (0.03 log units) above the measured number; the range from low to high includes it.
By their numbers in this assay, from the lowest: compounds 1 and 2 (each within the scatter of the next); then compounds 4 and 3 (each within the scatter of the next).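

In this assay, changing 2,3-dichlorophenyl to 2,6-dichlorophenyl gives a 1.3-fold lower number from compound 3 to compound 4 (0.11 log units; within the scatter), so at this position these two chlorine patterns cannot be told apart. The second chlorine still matters with either pattern: adding it to the single-chlorine benzyl group gives a 2.8-fold higher number from compound 2 to compound 4 (0.45 log units; beyond the scatter) here too, and the full group on the core of compound 1 gives a 4.7-fold higher number from compound 1 to compound 4 (0.67 log units; beyond the scatter) in a modest step. Nothing available explains why the two patterns read alike.

From the compounds shown here alone, whether other dichlorophenyl patterns would match these two remains open. So does whether a methoxy group or a carboxylic acid in place of chlorine, or a longer chain from the amine nitrogen in the ring to the aromatic ring, would bring the number back towards that of compound 2.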